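The compounds below may be only part of what the source reports. "The series", "measured", "known", "first", "only" and "open" are said of these compounds alone.

Measured in a toxicity assay on the whole organism (strain Icem-CET (SPF Caw)) for cytotoxicity, with Mus musculus as the target; on this read-out lower numbers stand for an effect already at smaller amounts and higher numbers for an effect only at larger amounts of compound:
compound 1 `C#CCNC(=O)/C(C)=C(\C)c1ccc(Cl)cc1`: 60 mg/kg
compound 2 `C=CCNC(=O)/C(C)=C(\C)c1ccc(OC)cc1`: 200 mg/kg
compound 3 `C=CCNC(=O)/C(C)=C(/C)c1ccc(OC)cc1`: 280 mg/kg

Compound 2 sits near the top of the three numbers. The move a 1.4-fold higher number from compound 2 to compound 3 (0.15 log units; within the scatter) is within the scatter, and the fact that compounds 2 and 3 differ only in the configuration as drawn shows that these two compounds differ only in the drawn configuration of the double bond, so compound 2 and compound 3 are not separated on this read-out. Compound 1 stands apart from compound 2 with a lower number beyond the scatter; it differs from compound 2 in two places at once, a propargyl chain for the allyl chain and chloro for methoxy, so its value cannot be assigned to either change alone.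

Compound 4 `C=CCNC(=O)/C(C)=C(\C)c1ccc(Cl)cc1` is to be measured in this assay. It differs from compound 2 by chloro in place of methoxy on an aromatic carbon. Of the measured steps only the drawn-configuration step exists, and it does not touch this change; the pair compound 1 and compound 2 shows only that the chloro-bearing propargyl amide gives a lower number than the methoxy-bearing allyl amide. With compound 1 carrying the same chloro group and giving 60 mg/kg, a step toward a lower number is expected, roughly a 2.2-fold lower number from compound 2 to compound 4 (0.35 log units; beyond the scatter). For compound 4 the estimate is 90 mg/kg, within a range from 45 mg/kg to 180 mg/kg.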

Compound 4, dose for half-maximal effect: 70 mg/kg
Beside the measured number, compound 4's estimate is 1.3-fold (0.11 log units) above it; low and high end bracket the measured number.
By their numbers in this assay, from the lowest: compounds 1 and 4 (each within the scatter of the next); then compounds 2 and 3 (each within the scatter of the next).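

In this assay, chloro in place of methoxy on an aromatic carbon, para to a large group, can now be read as a single change, with the allyl amide held constant: the exchange gives a 2.9-fold lower number from compound 2 to compound 4 (0.46 log units; beyond the scatter), a modest step. With chloro held constant, vinyl in place of ethynyl on a saturated chain carbon bound to an amide-type nitrogen gives a 1.2-fold higher number from compound 1 to compound 4 (0.07 log units; within the scatter), so the two chains are not separated on this read-out, and the gap between compound 1 and compound 2, which could not be divided before, goes with the aromatic exchange in these compounds rather than with the chain. Going by these compounds alone, the only available evidence concerns the drawn configuration of the double bond and has no bearing on either the aromatic or the chain exchange, so neither step can be given a cause here.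

As far as these compounds go, it remains open whether the chloro for methoxy step keeps its size on the other drawn configuration of the double bond, as in compound 3, or on the propargyl amide. Also open, from the compounds shown here alone, is how other groups would read at the same aromatic carbon, such as fluoro, trifluoromethyl, an amine or a carboxylic acid, and how a longer chain would read on the amide nitrogen.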